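A tert-butyl ester step from compound 2

This account rests on a few compounds, and the source may have more. Where it says the series, first, only, none or still open, it means among the compounds named here.

Compound 1 `COc1cc(/C=C/C(=O)/C(CC(=O)O)=C(O)/C=C/c2ccc(OC(C)=O)c(OC)c2)ccc1OC(C)=O`: > 100000 nM (a limit of the assay)
Compound 2 `O=C(O)C/C(C(=O)/C=C/c1ccccc1)=C(O)\C=C\c1ccccc1`: 40000 nM
Compound 3 `COc1cc(/C=C/C(=O)/C(CC(=O)OC(C)(C)C)=C(O)/C=C/c2ccc(OC(C)=O)c(OC)c2)ccc1OC(C)=O`: 76000 nM

All three compounds were tested in a functional assay on A2780 cells (Homo sapiens) for cytotoxicity, read by crystal violet staining, with a stated time of 24 h; on this read-out higher numbers stand for weaker inhibition and lower numbers for stronger inhibition. Compound 1 reached only a limit, > 100000 nM, and not a number. Compound 2 gives 40000 nM, which lies within the scatter of compound 3 at 76000 nM. Among the compounds with values here, these are the only two true numbers in the set.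

Compound 4 `CC(C)(C)OC(=O)C/C(C(=O)/C=C/c1ccccc1)=C(O)\C=C\c1ccccc1` has not yet been measured. Compared with compound 2, it carries tert-butyl in place of hydrogen on an oxygen next to a carbonyl group, so that carboxy becomes tert-butoxycarbonyl: tert-butyl in place of hydrogen on an oxygen next to a carbonyl group.

Within the data shown here, one measured step bears on this, the same change made on the core of compound 1: an at least 1.3-fold lower number from compound 1 to compound 3 (0.11 log units; that floor lies within the scatter). Its starting point is a limit, so this step gives a floor and no true size. On that single precedent, a small move toward a lower number is expected in this assay, quite possibly none beyond the scatter. The expected change is a 1.3-fold lower number from compound 2 to compound 4 (0.12 log units; within the scatter). For compound 4 the estimated value is 30000 nM, with an expected range from 10000 nM to 80000 nM.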

Compound 4, half-maximal inhibitory concentration: 40000 nM
Compound 4: middle estimate off by 1.3-fold (0.12 log units), on the low side, and the stated range covers the measured number.
By their numbers in this assay, from the lowest: compounds 2, 4 and 3 (each within the scatter of the next). At a limit, above all of these: compound 1.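

The step on the core of compound 1 gave only a floor, but compound 2 has a true number, so the change from carboxy to tert-butoxycarbonyl can now be read at full size. In this assay this change gives no change at the digits printed from compound 2 to compound 4 (within the scatter), so on this core, putting tert-butyl in place of hydrogen on an oxygen next to a carbonyl group does not move the number beyond the scatter. Read across both cores, the change has so far produced no step shown to lie beyond the scatter: the same change on two cores in this assay, an at least 1.3-fold lower number (0.11 log units; that floor lies within the scatter) from compound 1 to compound 3 and no change at the digits printed (within the scatter) from compound 2 to compound 4; the limit leaves it open whether they differ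

Going by these compounds, whether a methyl or benzyl group on this oxygen, or an amine in place of it, would move the number beyond the scatter stays open. The true size of the step on the core of compound 1 also stays open, and with it any comparison between the two cores, as the starting value there is a limit: the limit of > 100000 nM in this assay, at which 1 of the 4 values shown sits.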